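Swapping fluoro for ethoxy on a cytotoxic scaffold

The compounds below may be only part of what the source reports. "The series", "measured", "known", "first", "only" and "open" are said of these compounds alone.

- compound 1 `C=C1C(=O)[C@]23C[C@@]1(O)CC[C@H]2[C@@]12C=CC(=O)[C@](C)(C(=O)O1)[C@H]2[C@@H]3C(=O)OC`: 90900 nM
- compound 2 `C=C1C(=O)[C@]23C[C@@]1(F)CC[C@H]2[C@@]12C=CC(=O)[C@](C)(C(=O)O1)[C@H]2[C@@H]3C(=O)OC`: 38900 nM
- compound 3 `C=C1C(=O)[C@]23C[C@@]1(F)CC[C@H]2[C@@]12C=CC(=O)[C@](C)(C(=O)O1)[C@H]2[C@@H]3C(=O)OCc1ccccc1`: 64400 nM

In a functional assay on A549 cells (Homo sapiens) for cytotoxicity, read by MTT assay (on this read-out higher numbers stand for weaker inhibition and lower numbers for stronger inhibition), compound 2 gives 38900 nM, which sets it apart from compound 1 only modestly: a 2.3-fold lower number from compound 1 to compound 2 (0.37 log units; beyond the scatter). Compound 3 cannot be told apart from it: a 1.7-fold higher number from compound 2 to compound 3 (0.22 log units; within the scatter). Compound 4 `C=C1C(=O)[C@]23C[C@@]1(OCC)CC[C@H]2[C@@]12C=CC(=O)[C@](C)(C(=O)O1)[C@H]2[C@@H]3C(=O)OC` carries ethoxy in place of fluoro on a saturated ring carbon. Among the compounds with values here, only the step from hydroxy to fluoro touched this carbon, and no ether has been measured there. Ethoxy, like hydroxy, joins through oxygen, so a small rise in the number is expected, partly undoing that modest step. The expected step is a 1.4-fold higher number from compound 2 to compound 4 (0.15 log units; within the scatter). For compound 4 the estimate is 55000 nM, with an expected range from 22000 nM to 120000 nM.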

Compound 4, half-maximal inhibitory concentration: 18200 nM
The estimate for compound 4 lay 3.0-fold (0.48 log units) above the measured number; the whole stated range lies above it.
By their numbers in this assay, from the lowest: compound 4; then compounds 2, 3 and 1 (each within the scatter of the next, the first and the last beyond it).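

In this assay, ethoxy in place of fluoro on this saturated ring carbon gives a 2.1-fold lower number from compound 2 to compound 4 (0.33 log units; beyond the scatter), so joining through oxygen does not by itself bring back the higher number of compound 1. Putting ethyl on the oxygen of compound 1 gives a 5.0-fold lower number from compound 1 to compound 4 (0.70 log units; beyond the scatter), the largest step yet seen at this carbon, so a hydroxy and an ether on the same oxygen differ clearly here. Nothing available explains this difference. Open questions are whether a longer chain such as propoxy, or an amine, would lower the number further, and whether ethoxy gives a similar step alongside the ester of compound 3.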